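Weak succinate receptor antagonists: adding a trifluoromethyl group

The source may report more compounds than this note shows. Statements on the series, on what has been measured and on what is new or still open speak of the compounds shown alone.

Compound 1 `FC(F)(F)c1ccc(-c2nnc(CCCCc3ccc4cccnc4n3)o2)cc1`: 3000 nM
Compound 2 `Clc1ccc(-c2nnc(CCCCc3ccc4cccnc4n3)o2)cc1`: > 3000 nM

Both measured compounds share a core and differ only in the group on the outer benzene ring. Among the measured compounds shown here, in a functional assay on CHO-K1 cells for antagonist activity at succinate receptor 1 (Homo sapiens), read by FLIPR and calcium flux (a lower number here means a stronger inhibitor, a higher number a weaker inhibitor), compound 1 gives 3000 nM, the only actual number in the set. For compound 2 the assay gives only a limit, > 3000 nM, which tells that its inhibition was too weak to be measured as a number. The step of a number no lower from compound 1 to compound 2 (the limit leaves the size open), chloro in place of trifluoromethyl on an aromatic carbon, therefore cannot be sized, and its only support is the limit of > 3000 nM in this assay, at which 1 of the 2 values shown sits.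

Compound 3 `FC(F)(F)c1ccc(-c2nnc(CCCCc3ccc4cccnc4n3)o2)cc1C(F)(F)F` is not yet measured. It differs from compound 1 by trifluoromethyl in place of hydrogen on an aromatic carbon. For the measured compounds named here, no measured step adds a group at a position ortho to a trifluoromethyl group, so the step of a number no lower from compound 1 to compound 2 (the limit leaves the size open) bears on this change only loosely: it shows that altering this ring did not improve potency. With compound 1 already weak, compound 3 is estimated at 3000 nM, in the range 1000 nM to 10000 nM, a step of no change at the digits printed from compound 1 to compound 3 (within the scatter) that is expected to stay within the usual scatter, with a fair chance that only a limit is reported.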

Compound 3, half-maximal inhibitory concentration: 170 nM
Compound 3: middle estimate off by 18-fold (1.25 log units), on the high side; measured number below the stated range.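

In this assay, among the compounds shown here, the step of an 18-fold lower number from compound 1 to compound 3 (1.25 log units; beyond the scatter) is the first change in this set whose size can be read, and it shows that this ring position, ortho to a trifluoromethyl group and meta to a large group, accepts a second trifluoromethyl with a large gain in potency. For the compounds shown here, until now, the only information on changing this ring was a swap of one group for another that could not be sized: the limit of > 3000 nM in this assay, at which 1 of the 3 values shown sits. The weak result for compound 1 is therefore not fixed by the shared core, since adding one group of 4 heavy atoms, with no ring, no hydrogen-bond donors or acceptors and no net charge, gives compound 3 a value of 170 nM.

The compounds shown leave open whether the gain belongs to trifluoromethyl itself or whether a methyl group or a nitrile at the same position would give a similar result. They also leave open whether the first trifluoromethyl is still needed once the second is present, and why this single addition has so large an effect.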